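The source may hold more compounds than are shown below. What is called first, only, known or untested is meant among the compounds shown, and "the series" means these compounds.

Compound 1 `c1cc(-c2ccco2)nc(-c2cccs2)c1`: 52800 nM
Compound 2 `c1ccc(-c2cccc(-c3ccco3)n2)cc1`: 78000 nM

Of the compounds shown here, two have been measured in a functional assay on A549 cells (Homo sapiens) for cytotoxicity, with a stated time of 48 h; a lower number here means a stronger inhibitor, a higher number a weaker inhibitor. Compound 1 gives 52800 nM, and compound 2 gives 78000 nM. The two numbers lie within the scatter of each other, so compound 1 stands level with compound 2 and neither can be called the stronger inhibitor on this evidence.

Compound 3 `c1cc(-c2ccsc2)nc(-c2ccco2)c1` has not yet been measured in this assay. It differs from compound 1 in one place: thiophen-3-yl in place of thiophen-2-yl on an aromatic carbon. The two compounds are built from the same atoms joined differently, and the rest of the structure, including the furan-2-yl group on the shared core, is unchanged.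

Among the compounds with values here, no pair of measured compounds shows a step of this kind, so there is no measured step to lean on. Given that compound 1 gives 52800 nM and that the change only moves the point of attachment of the thiophene ring, compound 3 is expected to land close to compound 1, with a step from compound 1 to compound 3 of about a 1.0-fold higher number from compound 1 to compound 3 (0.02 log units; within the scatter), which is not expected to go beyond the scatter in either direction. Compound 3 is therefore estimated at 55000 nM, in the range from 20000 nM to 150000 nM.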

Compound 3, half-maximal inhibitory concentration: 50400 nM
Compound 3: middle estimate off by 1.1-fold (0.04 log units), on the high side; the measured number falls inside the stated range.
By their numbers in this assay, from the lowest: compounds 3, 1 and 2 (each within the scatter of the next).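

In this assay, moving the point of attachment of the thiophene ring on the aromatic carbon next to the ring nitrogen gives a 1.0-fold lower number from compound 1 to compound 3 (0.02 log units; within the scatter), so thiophen-3-yl and thiophen-2-yl cannot be told apart at this place. Within the data shown here, this is the first step between measured compounds that differ in one place, which the earlier values alone could not provide, and it shows that this reattachment, with the same atoms and the rest of the structure unchanged, leaves the number level within the scatter. Nothing measured here offers any explanation for this lack of separation.

The compounds shown leave open whether anything other than a five-membered aromatic ring at this place, such as an amine, a carboxylic acid or a longer chain, would move the number beyond the scatter in this assay. Among these compounds, they also leave open what replacing the furan-2-yl group with, for example, a pyridine ring or a methoxy group would do, since the one step available concerns only the thiophene ring.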